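Cyano for Trifluoromethoxy on a Shared Core

The source may report more compounds than this note shows. Statements on the series, on what has been measured and on what is new or still open speak of the compounds shown alone.

Compound 3 `FC(F)(F)Oc1cc2[nH]ncc2cc1-c1ccccc1C(F)(F)F` gives 36 nM in an assay on CHO-TREX cells for antagonist activity at transient receptor potential cation channel subfamily A member 1 (Homo sapiens), read by FLIPR and calcium flux, with a stated time of 10 min (a higher number here means a weaker inhibitor, a lower number a stronger inhibitor), and stands at the low end of the three numbers, though compound 1 `Fc1cc2[nH]ncc2cc1-c1ccccc1C(F)(F)F` at 48 nM and compound 2 `FC(F)(F)c1ccccc1-c1cc2cn[nH]c2cc1C1CC1` at 61 nM both lie within the scatter of it. Compound 4 `N#Cc1cc2[nH]ncc2cc1-c1ccccc1C(F)(F)F` carries cyano in place of trifluoromethoxy on an aromatic carbon. The two steps at this same position, a 1.3-fold lower number from compound 1 to compound 3 (0.12 log units; within the scatter) and a 1.7-fold lower number from compound 2 to compound 3 (0.23 log units; within the scatter), were both within the scatter, so fluoro, cyclopropyl and trifluoromethoxy land close together there. The chemist therefore expects the cyano group to give no step beyond the scatter, a 1.4-fold higher number from compound 3 to compound 4 (0.14 log units; within the scatter). The estimate for compound 4 is 50 nM, with an expected range from 20 nM to 130 nM.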

Compound 4, half-maximal inhibitory concentration: 129 nM
For compound 4 the middle estimate is 2.6-fold (0.41 log units) below the measured one; low and high end bracket the measured number.
By their numbers in this assay, from the lowest: compounds 3, 1 and 2 (each within the scatter of the next); then compound 4.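

Among the compounds shown here, at this position the choice of group does matter in this assay: cyano is the first group to stand apart, beyond the scatter from trifluoromethoxy (a 3.6-fold higher number from compound 3 to compound 4 (0.55 log units; beyond the scatter)), fluoro (a 2.7-fold higher number from compound 1 to compound 4 (0.43 log units; beyond the scatter)) and cyclopropyl (a 2.1-fold higher number from compound 2 to compound 4 (0.33 log units; beyond the scatter)). All three steps are modest and point the same way, so compound 4 alone sits on the side of the higher number. Nothing shown here accounts for this difference.

As far as these compounds go, whether the higher number is particular to cyano remains open, as does how an amine or a carboxylic acid on this aromatic carbon would compare.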